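Swapping a Methoxy for a Methylpiperidine on the Aryl Ring

This account rests on a few compounds, and the source may have more. Where it says the series, first, only, none or still open, it means among the compounds named here.

Compound 2 `COc1cc(-c2cn(C(=O)NCCCCc3ccccc3)c(=O)o2)ccc1F` is one of two molecules measured in an assay on isolated protein for inhibition of acid ceramidase (Homo sapiens), read by LC-MS, with a stated time of 1 h; on this read-out lower numbers stand for stronger inhibition and higher numbers for weaker inhibition. There compound 2 gives 80 nM, while compound 1 `O=C(NCCCCc1ccccc1)n1cc(-c2ccc(Cl)cc2)oc1=O` gives 83 nM; the two numbers lie within the scatter of each other, so neither can be called the stronger inhibitor. Among the compounds with values here, the only measured step, a 1.0-fold lower number from compound 1 to compound 2 (0.02 log units; within the scatter), put 4-fluoro-3-methoxyphenyl in place of 4-chlorophenyl and left the number essentially unchanged. Compound 3 `CN1CCC(c2cc(-c3cn(C(=O)NCCCCc4ccccc4)c(=O)o3)ccc2F)CC1` has not been measured yet. It differs from compound 2 by 1-methylpiperidin-4-yl in place of methoxy on an aromatic carbon. Within the data shown here, no measured step bears directly on this change, as the only one exchanged the whole aromatic substituent rather than the methoxy alone, so there is little to lean on. The expectation for compound 3 is a step of a 1.3-fold higher number from compound 2 to compound 3 (0.10 log units; within the scatter) in this assay, nothing beyond the scatter, giving an estimated value of 100 nM in a range from 30 nM to 400 nM.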

Compound 3, half-maximal inhibitory concentration: 341 nM
Beside the measured number, compound 3's estimate is 3.4-fold (0.53 log units) below it; the range from low to high includes it.
By their numbers in this assay, from the lowest: compounds 2 and 1 (each within the scatter of the next); then compound 3.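

On an aromatic carbon ortho to a fluoro group, 1-methylpiperidin-4-yl in place of methoxy gives a 4.3-fold higher number from compound 2 to compound 3 (0.63 log units; beyond the scatter) in this assay. Within the data shown here, this is the first step that lies beyond the scatter, so the group at this position does affect inhibition, although the loss is modest and compound 3 still gives a measurable number. No measured evidence here explains the loss.

Two compounds with a single change at this carbon cannot show whether the larger ring or its nitrogen matters more. A cyclohexyl group, which keeps a six-membered ring without the nitrogen, and a smaller amine such as dimethylamino would be the natural comparisons for separating those two features.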